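Isopropylcarbamoyl for methoxy in a cytotoxicity series

This account rests on a few compounds, and the source may have more. Where it says the series, first, only, none or still open, it means among the compounds named here.

In an ADME assay on HEK293 cells (Homo sapiens) for cytotoxicity, with a stated time of 6 h (on this read-out lower numbers stand for higher toxicity in this test and higher numbers for lower toxicity in this test), compound 2 `CCCCNc1nc(N)nc2cccc(OC)c12` gives only a limit, > 25000 nM. Compound 3 `CCCCNc1nc(N)nc2cccc(OCc3ccccc3OC)c12` also gives only a limit, > 25000 nM. Compound 1 `CCCCNc1nc(N)nc2cc(CN(C)C)ccc12` is again a limit, > 18000 nM. Compound 2 therefore stands without a number, and so do the other two. Going by the values given here, the only measured step, a step that the two limits leave unreadable from compound 2 to compound 3, puts 2-methoxyphenyl in place of hydrogen on a saturated chain carbon bound to an oxygen on an aromatic ring. Compound 4 `CCCCNc1nc(N)nc2cccc(C(=O)NC(C)C)c12` carries isopropylcarbamoyl in place of methoxy on an aromatic carbon, (isopropylcarbamoyl in place of methoxy on an aromatic carbon). No step beyond the scatter is expected in this assay, since compound 3 stayed at the limit > 25000 nM. The expected move is a step that the limit leaves unreadable from compound 2 to compound 4. For compound 4 the estimated value is 30000 nM, within an expected range of 15000 nM to 60000 nM.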

Compound 4, half-maximal cytotoxic concentration: > 25000 nM
Compound 4: only a limit was reported; the forecaster's own chance of this, stated with the estimate: 85%; the middle value is on the limit's open side.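

Compound 2 and compound 4 are both reported only as limits, so the step between them cannot be read. The compounds shown leave open the actual half-maximal cytotoxic concentration of each of them.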